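A few compounds are considered here, and "the series" means these few. Any claim that something is new, unique, unknown or untested is made for them only; others in the source may bear on it.

Compound 1 `CC/C=C\C[C@H]1C(=O)C=C[C@H]1CC(=O)OCCO` gives 24000 nM
Compound 2 `CC/C=C\C[C@H]1C(=O)C=C[C@H]1CC(=O)OCCOCCO` gives 36000 nM
Compound 3 `CC/C=C\C[C@H]1C(=O)C=C[C@H]1CC(=O)OCCOCCOC` gives 33000 nM

These numbers come from a functional assay on RAW264.7 cells (Mus musculus) for inhibition, read by ELISA, with a stated time of 24 h (a lower number here means that less compound is needed, a higher number that more compound is needed for the effect), and they lie close together. Compound 3 gives 33000 nM and cannot be told apart from the other two, with a 1.1-fold lower number from compound 2 to compound 3 (0.04 log units; within the scatter) and a 1.4-fold higher number from compound 1 to compound 3 (0.14 log units; within the scatter) as the measured steps.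

The change to compound 4 `CC/C=C\C[C@H]1C(=O)C=C[C@H]1CC(=O)OCCOCCOCCOC` is methoxymethyl in place of hydrogen on a saturated chain carbon bound to an oxygen on a saturated carbon and, cut one bond further out, it reads methoxy to 2-methoxyethoxy. The chain therefore grows again at the same end. For the measured compounds named here, two measured steps bear on this. One is a 1.4-fold higher number from compound 1 to compound 3 (0.14 log units; within the scatter) for 2-methoxyethyl in place of hydrogen on an oxygen on a saturated carbon, and the other is a 1.5-fold higher number from compound 1 to compound 2 (0.18 log units; within the scatter) for 2-hydroxyethyl in the same place. Both were small, so no step beyond the scatter is expected in this assay in either direction. The expected change is a 1.1-fold higher number from compound 3 to compound 4 (0.03 log units; within the scatter) and it remains an estimate. The estimate for compound 4 is 35000 nM and its expected range runs from 20000 nM to 60000 nM on this reasoning.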

Compound 4, half-maximal effective concentration: 35000 nM
The estimate for compound 4 equals the measured number at the digits printed; low and high end bracket the measured number.
By their numbers in this assay, from the lowest: compounds 1, 3, 4 and 2 (each within the scatter of the next).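

In this assay, the chain can grow further at this end without a step that can be told apart: methoxymethyl in place of hydrogen on a saturated chain carbon bound to an oxygen on a saturated carbon gives a 1.1-fold higher number from compound 3 to compound 4 (0.03 log units; within the scatter). Even 2-(2-methoxyethoxy)ethyl, the longest group added to compound 1 here, gives only a 1.5-fold higher number from compound 1 to compound 4 (0.16 log units; within the scatter), and 2-methoxyethyl on the hydroxyl-ended chain gives a 1.0-fold lower number from compound 2 to compound 4 (0.01 log units; within the scatter). That same change can now be read twice, and the two readings agree: the same change on two cores in this assay, a 1.4-fold higher number (0.14 log units; within the scatter) from compound 1 to compound 3 and a 1.0-fold lower number (0.01 log units; within the scatter) from compound 2 to compound 4, 1.4-fold (0.15 log units) apart, within the scatter of two such steps.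

On these data alone, all four compounds stay within the scatter of one another, so what sets their shared level remains unknown. As far as these compounds go, whether an amine or a carboxylic acid at the end of the chain, or a much longer chain, would move the number stays open.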